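Methoxy Addition on a Second Anilino Core

The source may hold more compounds than are shown below. What is called first, only, known or untested is meant among the compounds shown, and "the series" means these compounds.

Compound 1 `COc1ccc(/C=C/C(=O)Nc2cc3c(Nc4ccc(Cl)c(Cl)c4)ncnc3s2)cc1`: 790 nM
Compound 2 `O=C(/C=C/c1ccccc1)Nc1cc2c(Nc3ccc(Cl)c(Cl)c3)ncnc2s1`: 480 nM
Compound 3 `O=C(/C=C/c1ccccc1)Nc1cc2ncnc(Nc3ccc(F)c(Cl)c3)c2s1`: 200 nM

Three compounds were measured in a functional assay on PC-3 cells (Homo sapiens) for antiproliferative activity, read by MTT assay, with a stated time of 48 h; on this read-out higher numbers stand for weaker inhibition and lower numbers for stronger inhibition. Compound 2 `O=C(/C=C/c1ccccc1)Nc1cc2c(Nc3ccc(Cl)c(Cl)c3)ncnc2s1` gives 480 nM there, and compound 1 `COc1ccc(/C=C/C(=O)Nc2cc3c(Nc4ccc(Cl)c(Cl)c4)ncnc3s2)cc1` gives 790 nM. Compound 1 differs from compound 2 by methoxy in place of hydrogen on an aromatic carbon, and that step is a 1.6-fold higher number from compound 2 to compound 1 (0.22 log units; within the scatter). Compound 3 `O=C(/C=C/c1ccccc1)Nc1cc2ncnc(Nc3ccc(F)c(Cl)c3)c2s1` gives 200 nM in this assay; the difference between the core of compound 3 and the core of compound 2 is not broken down here. Compound 4 `COc1ccc(/C=C/C(=O)Nc2cc3ncnc(Nc4ccc(F)c(Cl)c4)c3s2)cc1` has not yet been measured in this assay. For the measured compounds named here, it differs from compound 3 by methoxy in place of hydrogen on an aromatic carbon, which is the same kind of change as the one from compound 2 to compound 1. The step from compound 3 to compound 4 is expected to be about a 1.5-fold higher number from compound 3 to compound 4 (0.18 log units; within the scatter), because the same change gave a 1.6-fold higher number from compound 2 to compound 1 (0.22 log units; within the scatter). On that basis compound 4 is estimated at 300 nM in this assay, expected to lie between 150 nM and 650 nM.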

Compound 4, half-maximal inhibitory concentration: 100 nM
Compound 4: middle estimate off by 3.0-fold (0.48 log units), on the high side; the measured number lies below the stated range.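

In this assay, the new step is a 2.0-fold lower number from compound 3 to compound 4 (0.30 log units; within the scatter), so taken alone it does not establish that methoxy improves the number on the core of compound 3. Set beside the earlier step, however, the change does not carry from one core to the other as a constant increment, and the two steps differ by more than their scatter: the same change on two cores in this assay, a 1.6-fold higher number (0.22 log units; within the scatter) from compound 2 to compound 1 and a 2.0-fold lower number (0.30 log units; within the scatter) from compound 3 to compound 4, 3.3-fold (0.52 log units) apart, beyond the scatter of two such steps This shows that, in these two pairs, the outcome of going from phenyl to 4-methoxyphenyl depends on the rest of the molecule, but it does not show which part of the difference between the cores matters, and two pairs set no rule for the series.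

The compounds shown leave open whether another group in the same place, such as a hydroxy group, an amine or a chlorine atom, would also behave differently on the two cores. They also leave open whether the ring system or the halogens on the anilino ring account for the gap, as no pair shown changes one without the other.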